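This account rests on a few compounds, and the source may have more. Where it says the series, first, only, none or still open, it means among the compounds named here.

In a functional assay on NCI-H226 cells (Homo sapiens) for inhibition, read by MTT assay, with a stated time of 48 h, tested at 10 uM (a higher number here means more inhibition at the concentration tested (going by the name of the read-out), a lower number less inhibition), three close analogues have been measured. Compound 1 `Cc1ccc(Nc2cc(NC(=O)Nc3c(Cl)cccc3Cl)ncn2)cc1F` gives 40.7%. Compound 2 `COc1cc(NC(=O)Nc2cc(Nc3cccc(C(C)(C)C)c3)ncn2)cc(OC)c1` gives 40%, and compound 3 `CC(C)(C)c1ccc(Nc2cc(NC(=O)Nc3c(Cl)cccc3Cl)ncn2)cc1` gives 40%. Compound 2 thus sits level with compound 3 at the digits reported, and its gap to compound 1 also lies within the scatter, so the three numbers cannot be told apart. The next compound, compound 4 `COc1cc(NC(=O)Nc2cc(Nc3cc(I)ccc3OC)ncn2)cc(OC)c1`, has not yet been measured in this assay. It differs from compound 2 in one place: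
5-iodo-2-methoxyphenyl in place of 3-(tert-butyl)phenyl on a nitrogen on an aromatic ring
For the measured compounds named here, no step between two measured compounds isolates this change, so the expected step of no change at the digits printed from compound 2 to compound 4 (within the scatter) is one of no change beyond the scatter. Compound 4 is therefore expected to give about 40% in this assay, with a range from 25% to 55%.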

Compound 4, a percentage reported as inhibition, at one concentration (the size of the read-out at that concentration, not a potency): 56.7%
Compound 4: the middle estimate sits 16.7 percentage points below what was measured, and the stated range ends below it.
By their numbers in this assay, from the lowest: compounds 2, 3 and 1 (each within the scatter of the next); then compound 4.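

In this assay, 5-iodo-2-methoxyphenyl in place of 3-(tert-butyl)phenyl on a nitrogen on an aromatic ring gives a number 16.7 percentage points higher from compound 2 to compound 4 (beyond the scatter) for this one change. For the compounds shown here, the read-out at this place therefore depends on the group it carries, which the earlier compounds could not show, since no two of them differed in one place only. On these data alone, the iodo and methoxy groups arrive together, so the step cannot be assigned to either alone, and how a morpholine or a carboxylic acid would fare here remains open. Nothing available bears on why the number differs.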